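The source may report more compounds than this note shows. Statements on the series, on what has been measured and on what is new or still open speak of the compounds shown alone.

Measured so far in a functional assay on SF-539 cells (Homo sapiens) for inhibition; a lower number here means a stronger inhibitor of growth, a higher number a weaker inhibitor of growth:
- compound 1 `C=C1C(=O)O[C@H]2[C@H]1CC/C(COC(=O)N1CCC(F)(F)CC1)=C\CC[C@@]1(C)O[C@@H]21`: 1980 nM
- compound 2 `C=C1C(=O)O[C@H]2[C@H]1CC/C(COC(=O)NCCN1CCCC1)=C\CC[C@@]1(C)O[C@@H]21`: 15000 nM

Compound 2, at 15000 nM, holds the higher of the two numbers and is the weaker growth inhibitor of the pair. Among the measured compounds shown here, its nearest neighbour is compound 1, and the gap is the one measured step, a 7.6-fold higher number from compound 1 to compound 2 (0.88 log units; beyond the scatter). That step put (2-(pyrrolidin-1-yl)ethyl)amino in place of 4,4-difluoropiperidin-1-yl on a carbonyl carbon.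

Next is compound 3 `C=C1C(=O)O[C@H]2[C@H]1CC/C(COC(=O)Nc1n[nH]c(SC)n1)=C\CC[C@@]1(C)O[C@@H]21`, with the change (5-(methylsulfanyl)-1H-1,2,4-triazol-3-yl in place of 2-(pyrrolidin-1-yl)ethyl on an amide-type nitrogen). It sits on an amide-type nitrogen, and the rest of the structure is unchanged. For the measured compounds named here, no measured compound carries 5-(methylsulfanyl)-1H-1,2,4-triazol-3-yl, so the evidence is indirect. Going by the values given here, the step from compound 1 shows only that the group on this carbonyl can shift the number beyond the scatter, by a 7.6-fold higher number from compound 1 to compound 2 (0.88 log units; beyond the scatter).

A modest move to a lower number in this assay is expected, part of the way back towards compound 1 at 1980 nM. The expected step is a 2.5-fold lower number from compound 2 to compound 3 (0.40 log units; beyond the scatter). Compound 3 is estimated at 6000 nM, with an expected range of 2000 nM to 18000 nM.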

Compound 3, concentration for 50% growth inhibition: 1760 nM
The estimate for compound 3 lay 3.4-fold (0.53 log units) above the measured number; measured number outside the range, below it.
By their numbers in this assay, from the lowest: compounds 3 and 1 (each within the scatter of the next); then compound 2.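

In this assay, the result gives an 8.5-fold lower number from compound 2 to compound 3 (0.93 log units; beyond the scatter), a shift on an amide-type nitrogen between two groups with the same heavy-atom count and no net charge, so neither of those counts separates 2-(pyrrolidin-1-yl)ethyl from 5-(methylsulfanyl)-1H-1,2,4-triazol-3-yl. Compound 3 keeps the amide hydrogen and still reads level with compound 1, which lacks it, at a 1.1-fold lower number from compound 1 to compound 3 (0.05 log units; within the scatter), so among these three compounds the amide hydrogen alone does not account for the high number of compound 2, and two very different groups on the carbonyl carbon, (5-(methylsulfanyl)-1H-1,2,4-triazol-3-yl)amino and 4,4-difluoropiperidin-1-yl, are indistinguishable here. No available data speak to why the number moves at this position.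

Still open, on these data alone, is whether the methylsulfanyl group matters, which a triazole carrying a plain hydrogen or a methyl group at that place would test, and whether a phenyl ring on the same nitrogen would read like compound 3. Equally open, as far as these compounds go, is whether the pyrrolidine ring or the ethyl chain goes with the high number of compound 2, which a 2-(morpholin-4-yl)ethyl or a 2-hydroxyethyl group would help to separate.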